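A few compounds are considered here, and "the series" means these few. Any claim that something is new, unique, unknown or untested is made for them only; others in the source may bear on it.

Working notes on the series, read by a functional assay on IC2 cells (Mus musculus) for cytotoxicity, read by MTT assay, with a stated time of 72 h; on this read-out lower numbers stand for stronger inhibition and higher numbers for weaker inhibition.

Of the compounds shown here, two of the shared core have numbers so far. Compound 1 `CNC1=C(Br)C(=O)c2ccncc2C1=O` carries a bromo substituent; in this assay compound 1 gives 0.22 ug/mL. Compound 2 `CNC1=C/C(=N\CCO)c2ccncc2C1=O`, which differs in more than one place, gives in this assay 0.1 ug/mL. On these two numbers compound 1 stands highest; its nearest neighbour is compound 2, whose number is lower by a margin beyond the scatter. Among the compounds with values here, no step between compounds differing in one place has been measured, so the series holds no calibrated single change yet.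

Compound 3 `CNC1=CC(=O)c2ccncc2C1=O` is the next candidate. Relative to compound 1 the change is hydrogen in place of bromo on a double-bonded ring carbon. Nothing measured here indicates the size of this step. In the absence of a reference, a modest movement toward a higher number is expected, but one that could fall within the scatter. The expected step is a 1.8-fold higher number from compound 1 to compound 3 (0.26 log units; within the scatter). For compound 3 in this assay the estimate is 0.4 ug/mL, with a range from 0.12 ug/mL to 1.3 ug/mL.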

Compound 3, half-maximal inhibitory concentration: 0.34 ug/mL
Estimate against measurement, compound 3: 1.2-fold (0.07 log units) above; the measured number falls inside the stated range.
By their numbers in this assay, from the lowest: compound 2; then compounds 1 and 3 (each within the scatter of the next).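

In this assay the series now has its first calibrated single change, hydrogen in place of bromo on a double-bonded ring carbon, next to the ring atom that bears a methylamino group, and it reads as a 1.5-fold higher number from compound 1 to compound 3 (0.19 log units; within the scatter). On this pair, the position does not separate bromo from hydrogen on this read-out, so the bromo substituent is not shown to be required for the cytotoxicity seen with the shared core, and a single bromine can leave this ring carbon without a step beyond the scatter. No measurement at hand accounts for this result, and a reading of the pair in terms of the properties of either group has no support.

Within the data shown here, one pair of substituents gives only one calibrated step, so it remains open whether a different group on this ring carbon, such as chloro, a methoxy group, an amine or a carboxylic acid, would stand apart from bromo and hydrogen. Going by these compounds, it also remains open whether the same replacement would read alike elsewhere on the shared core.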